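The source may hold more compounds than are shown below. What is called first, only, known or untested is meant among the compounds shown, and "the series" means these compounds.

Measured compounds:
compound 1 `CC(C)c1ccc(S(=O)(=O)n2cc(N3CCN(C)CC3)c3ccc(Cl)cc32)cc1`: in an assay on HeLa cells for displacement of a labelled ligand from 5-hydroxytryptamine receptor 6 (Homo sapiens) (on this read-out lower numbers stand for stronger inhibition and higher numbers for weaker inhibition), compound 1 gives 55.3 nM
compound 2 `CCN1CCN(c2cn(S(=O)(=O)c3ccc(C(C)C)cc3)c3ccccc23)CC1`: in this assay compound 2 gives 8.6 nM

Compound 2 holds the lower of the two numbers measured in this assay; compound 1 sits higher by a gap beyond the usual scatter. Among the compounds with values here, the two differ from each other in more than one place, so nothing in these numbers isolates a single change, and no step between measured compounds is available.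

Compound 3 `CCN1CCN(c2cn(S(=O)(=O)c3ccc(C(C)C)cc3)c3ccc(Cl)cc23)CC1` is the next member to be tested. It differs from compound 2 by chloro in place of hydrogen on an aromatic carbon. Compound 1 also carries a chloro group and stands higher than compound 2 in this assay, but compound 1 differs from compound 2 in a second place as well, so that comparison does not settle what the chloro group alone does. The expectation is therefore cautious: a shift towards a higher number, modest in size and possibly no larger than the scatter itself.

The step from compound 2 to compound 3 in this assay is expected to be a 1.7-fold higher number from compound 2 to compound 3 (0.24 log units; within the scatter). Compound 3 is estimated at 15 nM in this assay, with a range from 5 nM to 45 nM.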

Compound 3, inhibition constant: 30.5 nM
Compound 3: middle estimate off by 2.0-fold (0.31 log units), on the low side, within the range that was stated.
By their numbers in this assay, from the lowest: compound 2; then compounds 3 and 1 (each within the scatter of the next).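

In this assay, chloro in place of hydrogen on an aromatic carbon of the shared core now has a step of its own, a 3.5-fold higher number from compound 2 to compound 3 (0.55 log units; beyond the scatter), which lies beyond the scatter and shows that this position responds to the change, something the comparison of compound 1 with compound 2 could not isolate. Among the two chloro compounds, which differ only in carrying methyl or ethyl on the basic end of the molecule, compound 1 at 55.3 nM and compound 3 at 30.5 nM lie within the scatter of each other, so this pair shows no readable effect of that swap. No measurement at hand speaks to what lies behind the chloro step.

Going by these compounds, whether the step is specific to chloro remains open, since fluoro, methoxy or an amine on the same aromatic carbon would each test that directly. Also open, on these data alone, is whether chloro gives a similar step on other carbons of that six-membered ring, and whether a methyl-bearing analogue without chloro would follow the same trend.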